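Methylsulfonyl for cyano on a second fluorophenyl arrangement

The source may report more compounds than this note shows. Statements on the series, on what has been measured and on what is new or still open speak of the compounds shown alone.

Measured compounds, in a functional assay on CHO-K1 cells with Glucose-dependent insulinotropic receptor (Homo sapiens) as the target, read by a luciferase reporter, with a stated time of 5 h; on this read-out higher numbers stand for larger maximal responses and lower numbers for smaller maximal responses:
compound 1 `CC(C)OC(=O)N1CCC(Oc2ncnc3c2CCN3c2ccc(S(C)(=O)=O)cc2F)CC1`, 91%;
compound 2 `CC(C)OC(=O)N1CCC(Oc2ncnc3c2CCN3c2ccc(C#N)cc2F)CC1`, 134%;
compound 3 `CC(C)OC(=O)N1CCC(Oc2ncnc3c2CCN3c2ccc(C#N)c(F)c2)CC1`, 121%.

Compound 2 and compound 1 differ by methylsulfonyl in place of cyano on an aromatic carbon, and this step gave a number 43 percentage points lower from compound 2 to compound 1 (beyond the scatter). Compound 3 carries the same groups as compound 2 but joined differently, (4-cyano-3-fluorophenyl in place of 4-cyano-2-fluorophenyl on a nitrogen on an aromatic ring in a ring), with a number 13 percentage points lower from compound 2 to compound 3 (beyond the scatter); from compound 1 to compound 3 the read-out moved by a number 30 percentage points higher from compound 1 to compound 3 (beyond the scatter).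

Compound 4 `CC(C)OC(=O)N1CCC(Oc2ncnc3c2CCN3c2ccc(S(C)(=O)=O)c(F)c2)CC1` is not yet measured. It relates to compound 3 by methylsulfonyl in place of cyano on an aromatic carbon, the same kind of change as from compound 2 to compound 1, though the place differs: in compound 4 the site is ortho to a fluoro group, whereas in compound 1 it is meta to a fluoro group. Resting on compound 2 to compound 1 with a number 43 percentage points lower from compound 2 to compound 1 (beyond the scatter), a step of about a number 41 percentage points lower from compound 3 to compound 4 (beyond the scatter) is expected for compound 4. Compound 4 is therefore estimated at 80%, plausibly between 55% and 105%.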

Compound 4, largest response reached (reported as percent of maximum), in percent of the reference or control that the assay uses: 109%
The estimate for compound 4 lay 29 percentage points below the measured number, and the stated range ends below it.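

In this assay, methylsulfonyl in place of cyano did not carry over at one size from the core of compound 2 to the core of compound 3: the same change on two cores in this assay, a number 43 percentage points lower (beyond the scatter) from compound 2 to compound 1 and a number 12 percentage points lower (beyond the scatter) from compound 3 to compound 4, 31 percentage points apart, beyond the scatter of two such steps. The direction was shared, and the smaller step of a number 12 percentage points lower from compound 3 to compound 4 (beyond the scatter) left the fluoro arrangement of compound 4 ahead of the other methylsulfonyl compound, with a number 18 percentage points higher from compound 1 to compound 4 (beyond the scatter), though still short of the best nitrile, with a number 25 percentage points lower from compound 2 to compound 4 (beyond the scatter). These two pairs thus show that the direction carried over and the size did not, but they do not show why the sizes differ or how the change would behave on any other core.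

From the compounds shown here alone, whether an amine or a carboxylic acid in place of cyano would give the same direction on both arrangements stays open.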